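Amide in place of sulfonamide on the shared core

A few compounds are considered here, and "the series" means these few. Any claim that something is new, unique, unknown or untested is made for them only; others in the source may bear on it.

Compound 1 `COc1ccc(-c2cc(-c3ccc(S(N)(=O)=O)cc3)cnc2N)cn1` has been run in an in vitro ADME assay on microsomes from liver (Homo sapiens) for metabolic stability; a lower number here means slower removal, a higher number faster removal of the compound. In this assay compound 1 gives < 7 mL.min-1.g-1, which is a limit of the assay and not a number. Compound 2 `COc1ccc(-c2cc(-c3ccc4cnn(C)c4c3)cnc2N)cn1` shares the core but differs at more than one place; in this assay compound 2 gives 12 mL.min-1.g-1. Going by the values given here, the two values show only that compound 1 sits at the limit while compound 2 returns a number, and no step between them is counted. Compound 1 thus stands at the limit of < 7 mL.min-1.g-1 in this assay, at which 1 of the 2 values shown sits.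

Compound 3 `COc1ccc(-c2cc(-c3ccc(C(=O)N(C)C)cc3)cnc2N)cn1` has not yet been measured in this assay. It differs from compound 1 as dimethylcarbamoyl in place of sulfamoyl on an aromatic carbon, para to a large group. Among the compounds with values here, no measured step covers this change, so the expectation rests on the position of compound 1 alone. A modest step upward in this assay is expected from compound 1 to compound 3, an at least 1.7-fold higher number from compound 1 to compound 3 (0.23 log units; that floor lies within the scatter), with a real chance that the result again comes back as a limit. Compound 3 is estimated at 12 mL.min-1.g-1, range 6 mL.min-1.g-1 to 25 mL.min-1.g-1.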

Compound 3, intrinsic clearance in microsomes: 11.1 mL.min-1.g-1
The estimate for compound 3 lay 1.1-fold (0.03 log units) above the measured number, and the stated range covers the measured number.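

In this assay, dimethylcarbamoyl in place of sulfamoyl on an aromatic carbon, para to a large group, gives an at least 1.5-fold higher number from compound 1 to compound 3 (0.20 log units; that floor lies within the scatter). Going by these compounds alone, this is the first step read at this position, and it shows that the change moves the series from a limit to a number, though the step has only a floor and that floor lies within the scatter, so no real rise is established and its true size stays undefined. For compound 1 the reading remains a limit of the assay and not a number, which is what caps the step at a floor: the limit of < 7 mL.min-1.g-1 in this assay, at which 1 of the 3 values shown sits.

The compounds shown leave open whether the reading follows the carbonyl in place of the sulfonyl or the two methyl groups on the nitrogen, since both differ at once between compound 1 and compound 3; a primary carboxamide or a dimethylsulfamoyl group at the same place would separate the two. Also open, as far as these compounds go, is how this assay responds at this position to a carboxylic acid, an amine or a longer chain on the amide nitrogen.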